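Methoxy Removal in a Biaryl Furan Amide Series

A few compounds are considered here, and "the series" means these few. Any claim that something is new, unique, unknown or untested is made for them only; others in the source may bear on it.

Measured so far:
compound 1 `COc1ccc(-c2ccccc2)c2cc(C(=O)Nc3ccc(F)cc3)oc12`: "not determined" (no result reported) in a functional assay on the whole organism for inhibition, with Mus musculus as the target, at a dose of 10 mg/kg by the oral route; on this read-out lower numbers stand for less inhibition and higher numbers for more inhibition at the one dose given (going by the name of the read-out)
compound 2 `COc1ccc(-c2ccc(OC)c3oc(C(=O)Nc4ccc(Cn5ccnc5)cc4)cc23)cc1`: 54%

Among the compounds with values here, compound 2 holds the only number in hand; compound 1 carries no result in this assay. In this assay compound 2 gives 54%. Compound 3 `COc1ccc(-c2ccccc2)c2cc(C(=O)Nc3ccc(Cn4ccnc4)cc3)oc12` differs from compound 2 by hydrogen in place of methoxy on an aromatic carbon. Within the data shown here, no step between measured compounds exists, so any expectation rests on the structural change alone. A small downward step, barely beyond the usual scatter if at all, is expected, namely a number 8 percentage points lower from compound 2 to compound 3 (within the scatter). For compound 3 the estimate in this assay is 46%, with a range from 22% to 68%.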

Compound 3, a percentage reported as inhibition, in the whole organism at one dose (the size of the read-out at that dose, not a potency): 12%
Compound 3: middle estimate off by 34 percentage points, on the high side, and the stated range ends above it.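

Replacing methoxy with hydrogen, para to a large group, gives a number 42 percentage points lower from compound 2 to compound 3 (beyond the scatter) in this assay. The outcome at this dose therefore depends on what occupies this position, a dependence that could not be read before any step existed. No available data give a reason for the fall.

The compounds shown leave open whether the methoxy oxygen or the whole group matters. They also leave open how a hydroxyl, an ethoxy or an amine at this position would compare with compound 2.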